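From hydroxycarbamoyl to 2-(hydroxycarbamoyl)ethenyl on compound 2

This account rests on a few compounds, and the source may have more. Where it says the series, first, only, none or still open, it means among the compounds named here.

In a functional assay on KG-1 cells (Homo sapiens) for inhibition, read by MTT assay, with a stated time of 48 h (a lower number here means a stronger inhibitor, a higher number a weaker inhibitor), compound 2 `O=C(NO)c1ccc(Oc2no[n+]([O-])c2S(=O)(=O)c2ccccc2)cc1` gives 1240 nM. Compound 1 `O=C(CCCCCCCOc1no[n+]([O-])c1S(=O)(=O)c1ccccc1)NO` gives 630 nM and compound 3 `COc1cc(C(=O)NO)ccc1Oc1no[n+]([O-])c1S(=O)(=O)c1ccccc1` gives 1650 nM, and both of these numbers lie within the usual scatter of compound 2.

Compound 4 `O=C(/C=C/c1ccc(Oc2no[n+]([O-])c2S(=O)(=O)c2ccccc2)cc1)NO` differs from compound 2 in one place: 2-(hydroxycarbamoyl)ethenyl in place of hydroxycarbamoyl on an aromatic carbon. In words, 2-(hydroxycarbamoyl)ethenyl stands in place of hydroxycarbamoyl on an aromatic carbon.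

For the measured compounds named here, the only measured step, a 1.3-fold higher number from compound 2 to compound 3 (0.12 log units; within the scatter), is within the scatter, but it adds methoxy and leaves the hydroxycarbamoyl group unchanged, so it bears only loosely on this change. Compound 1 is closer in spirit, since its hydroxycarbamoyl group is not attached directly to an aromatic ring, and it gives 630 nM. No step beyond the scatter is therefore expected in this assay, with at most a slight lean towards a lower number. The expected step is a 1.5-fold lower number from compound 2 to compound 4 (0.16 log units; within the scatter). For compound 4 the estimated value is 850 nM, within an expected range of 300 nM to 2200 nM.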

Compound 4, half-maximal inhibitory concentration: 2750 nM
Estimate against measurement, compound 4: 3.2-fold (0.51 log units) below; measured number above the stated range.
By their numbers in this assay, from the lowest: compounds 1, 2, 3 and 4 (each within the scatter of the next, the first and the last beyond it).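

In this assay, 2-(hydroxycarbamoyl)ethenyl in place of hydroxycarbamoyl on this aromatic carbon, para to a large group, gives a 2.2-fold higher number from compound 2 to compound 4 (0.35 log units; beyond the scatter) and is a modest change, but it goes beyond the scatter. The earlier step, a 1.3-fold higher number from compound 2 to compound 3 (0.12 log units; within the scatter), added methoxy and left hydroxycarbamoyl untouched, so this is the first shown step that alters the group at this position itself and moves the number beyond the scatter. No measurement at hand accounts for this step.

From the compounds shown here alone, it remains open whether a saturated ethyl link in place of the ethenyl unit would give a similar number in this assay. Also open, going by these compounds, is how a carboxylic acid or an amine in place of the hydroxycarbamoyl group would behave at this position.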